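A methoxy removal tested against three compounds at the limit

The source may hold more compounds than are shown below. What is called first, only, known or untested is meant among the compounds shown, and "the series" means these compounds.

Compound 3 `COc1c(Br)cc(Br)cc1C(=O)Nc1ccc(Sc2nc3ccccc3s2)c(Cl)c1` carries a methoxy group that compound 1 `O=C(Nc1ccc(Sc2nc3ccccc3s2)c(Cl)c1)c1cc(Br)cc(Br)c1` lacks. In an assay on isolated protein for inhibition of thiosulfate sulfurtransferase (Homo sapiens), with a stated time of 60 min, in the absence of a further agent (on this read-out higher numbers stand for weaker inhibition and lower numbers for stronger inhibition), compound 3 gives > 100000 nM, which is a limit of the assay and not a number. Compound 1 gives > 100000 nM in this assay, again a limit. The change between them is hydrogen in place of methoxy on an aromatic carbon, and the step that the two limits leave unreadable from compound 3 to compound 1 cannot be read because of the limit of > 100000 nM in this assay, at which 3 of the 3 values shown sit. Compound 2 `COc1ccccc1C(=O)Nc1ccc(Sc2nc3ccccc3s2)cc1` gives > 100000 nM in this assay, once more a limit. The difference between the cores of compound 2 and compound 3 is not broken down here. Compound 4 `O=C(Nc1ccc(Sc2nc3ccccc3s2)cc1)c1ccccc1` has not been measured. It differs from compound 2 by hydrogen in place of methoxy on an aromatic carbon, the same kind of change as that from compound 3 to compound 1, though there the place was also ortho to a bromo group and para to a bromo group. Compound 4 is expected to give 200000 nM in this assay, most probably reported only as a limit. This expectation means a step that the limit leaves unreadable from compound 2 to compound 4. It rests on compound 2, whose value in this assay is > 100000 nM, a limit.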

Compound 4, half-maximal inhibitory concentration: > 100000 nM
Compound 4: no number, only a limit; the forecaster's own chance of this, stated with the estimate: 85%; the middle value is on the limit's open side.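

No new step can be read: compound 4, like compound 2, stands only at a limit in this assay, so the change from 2-methoxyphenyl to phenyl has no readable size, for this reason: the limit of > 100000 nM in this assay, at which 4 of the 4 values shown sit. The compounds shown leave open whether hydrogen in place of methoxy alters inhibition at all, since none of them gives an actual number.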